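Swapping the Furan for a Phenyl on the Shared Core

The source may report more compounds than this note shows. Statements on the series, on what has been measured and on what is new or still open speak of the compounds shown alone.

Compound 1, `CS(=O)(=O)Nc1cccc(-c2nc(C(c3ccc(F)cc3)c3ccc(F)cc3)sc2CC(=O)O)c1`: 80%
Compound 2, `O=C(O)Cc1sc(C(c2ccc(F)cc2)c2ccc(F)cc2)nc1-c1ccco1`: 80%

In an in vitro functional assay on HEK285-7 cells for antagonist activity at prostaglandin D2 receptor 2 (Homo sapiens), read by BRET and beta-arrestin recruitment (a lower number here means a smaller maximal response, a higher number a larger maximal response), compound 1 gives 80% and compound 2 gives 80%, so compound 2 stands level with compound 1 at the digits shown; the step of no change at the digits printed from compound 1 to compound 2 (within the scatter) lies within the scatter. Compound 3, `O=C(O)Cc1sc(C(c2ccc(F)cc2)c2ccc(F)cc2)nc1-c1ccccc1`, has not yet been measured. It differs from compound 2 as follows: phenyl in place of furan-2-yl on an aromatic carbon. Within the data shown here, the only measured step that bears on this position is the one from compound 1 to compound 2, where an aromatic group at this same carbon was exchanged and no change at the digits printed from compound 1 to compound 2 (within the scatter) was the result. Since that exchange left the maximal response unmoved, the writer expects the exchange of furan-2-yl for phenyl to behave alike, with no step beyond the scatter in this assay. The expected step is no change at the digits printed from compound 2 to compound 3 (within the scatter). Compound 3 is therefore estimated at 80%, with a range from 70% to 90%.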

Compound 3, largest response reached (reported as efficacy), in percent of the reference or control that the assay uses: 80%
Compound 3: middle estimate and measured number agree at the digits printed; low and high end bracket the measured number.
By their numbers in this assay, from the lowest: compounds 1, 2 and 3 (each within the scatter of the next).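

In this assay the exchange of furan-2-yl for phenyl gives no change at the digits printed from compound 2 to compound 3 (within the scatter) and so shows that, on this carbon, a six-membered aromatic ring of carbon only can stand for a five-membered aromatic ring with one hetero atom and one hydrogen-bond acceptor. Compound 3 also supplies a comparison the first two compounds could not give: hydrogen in place of methanesulfonamido on the phenyl ring gives no change at the digits printed from compound 1 to compound 3 (within the scatter) and so the maximal response here does not depend on that group. Nothing at hand explains why the response holds across these changes.

From the compounds shown here alone, all three compounds carry an aromatic ring on this carbon, so it remains open whether a methyl group or an amine there would hold the response. Going by these compounds, it is equally open whether any group at this position can move the response beyond the scatter.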